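The compounds below may be only part of what the source reports. "The series", "measured", "known", "first", "only" and "open" are said of these compounds alone.

In a functional assay on MCF7 cells (Homo sapiens) for inhibition, read by MTT assay, with a stated time of 72 h (a lower number here means a stronger inhibitor, a higher number a weaker inhibitor), compound 1 (`COc1cc(NC(C)CCCNC(=O)Nc2ccc(Br)cc2)c2ncccc2c1`) gives 2600 nM and compound 2 (`COc1cc(NC(C)CCCNC(=O)NNC(=O)Nc2ccc(C(F)(F)F)cc2)c2ncccc2c1`) gives 100 nM as the lower of the two numbers. Compound 2 is therefore the stronger inhibitor of this pair, by a gap beyond the usual scatter. These two compounds differ in more than one place, so their gap cannot be pinned on any single change.

Compound 3 (`COc1cc(NC(C)CCCNC(=O)NNC(=O)Nc2ccc(Br)cc2)c2ncccc2c1`) has not yet been measured. Its difference from compound 2 is bromo in place of trifluoromethyl on an aromatic carbon and amounts to bromo in place of trifluoromethyl on an aromatic carbon. Within the data shown here, no measured pair shows this exchange on its own, so the expectation starts from compound 2 at 100 nM and allows a wide margin. A small move toward a higher number in this assay is expected, most likely not beyond the scatter. The estimated change is a 1.8-fold higher number from compound 2 to compound 3 (0.26 log units; within the scatter) and remains uncertain. For compound 3 the estimated value is 180 nM with an expected range from 60 nM to 600 nM in this measurement.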

Compound 3, half-maximal inhibitory concentration: 100 nM
Beside the measured number, compound 3's estimate is 1.8-fold (0.26 log units) above it; measured number inside the range.
By their numbers in this assay, from the lowest: compounds 2 and 3 (each within the scatter of the next); then compound 1.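

In this assay, bromo in place of trifluoromethyl on an aromatic carbon para to a large group gives no change at the digits printed from compound 2 to compound 3 (within the scatter), so within this pair the two groups cannot be told apart at this position. With bromo present on both sides, the one-place change that the first two compounds could not show can now be read: ((4-bromophenyl)carbamoyl)amino in place of 4-bromophenyl on an amide-type nitrogen gives a 26-fold lower number from compound 1 to compound 3 (1.41 log units; beyond the scatter), a large step that lies beyond the scatter and far exceeds the step at the aromatic carbon. Nothing available gives a reason for either result.

As far as these compounds go, it remains open whether an amine or a carboxylic acid on that aromatic carbon would also leave the number in this assay in the same place as bromo and trifluoromethyl. From the compounds shown here alone, it is also open whether the large step at the amide-type nitrogen would hold with trifluoromethyl on the ring in place of bromo, or whether a longer chain at that nitrogen would give a step of similar size.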